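Cyanomethoxy oxime ether removal in a thioether series

The compounds below may be only part of what the source reports. "The series", "measured", "known", "first", "only" and "open" are said of these compounds alone.

Measured compounds:
compound 1 `CO[C@]1(c2cc(F)cc(Sc3ccc(/C(C)=N/OCC#N)cc3)c2)CCO[C@@H](C)C1` — 40 nM
compound 2 `COC1(c2csc(Sc3ccc4c(c3)OCC/C4=N\OCC#N)c2)CCOCC1` — 60 nM
compound 3 `C/C(=N\OCC#N)c1ccc(Sc2cc(F)cc(C3CCOCC3)c2)cc1` — 20 nM

In a functional assay (blood) for inhibition, with Homo sapiens as the target (on this read-out lower numbers stand for stronger inhibition and higher numbers for weaker inhibition), compound 1 gives 40 nM, the second highest of the three numbers. Its nearest neighbour is compound 2 at 60 nM, and the furthest is compound 3 at 20 nM; both gaps lie within the scatter, so no order among the three can be claimed. Within the data shown here, the one step between measured compounds that differ in a single place, a 2.0-fold lower number from compound 1 to compound 3 (0.30 log units; within the scatter), concerns the oxan-4-yl in place of 4-methoxy-2-methyloxan-4-yl and is itself within the scatter.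

Compound 4 `CO/N=C(\C)c1ccc(Sc2cc(F)cc([C@@]3(OC)CCO[C@@H](C)C3)c2)cc1` is not yet measured. Relative to compound 1 the difference is hydrogen in place of cyano on a saturated chain carbon bound to an oxygen; cut one bond further out it reads cyanomethoxy to methoxy. Among the measured compounds shown here, no measured pair bears on this change: all three measured compounds carry the cyanomethoxy group, and the single step available, from compound 1 to compound 3, touches a different part of the molecule. The expectation therefore rests on compound 1 alone, with a wide range. A modestly higher number than 40 nM for compound 1 is taken as the estimate, though a result within the scatter of compound 1 is equally plausible.

Compound 4 is estimated at 100 nM, range 30 nM to 400 nM, an expected step of a 2.5-fold higher number from compound 1 to compound 4 (0.40 log units; beyond the scatter).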

Compound 4, half-maximal inhibitory concentration: 140 nM
Compound 4: middle estimate off by 1.4-fold (0.15 log units), on the low side; the measured number falls inside the stated range.
By their numbers in this assay, from the lowest: compounds 3, 1 and 2 (each within the scatter of the next, the first and the last beyond it); then compound 4.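

In this assay, the oxime ether end of the molecule proves sensitive: hydrogen in place of cyano on a saturated chain carbon bound to an oxygen gives a 3.5-fold higher number from compound 1 to compound 4 (0.54 log units; beyond the scatter), the only step beyond the scatter among the single-place pairs shown. Among these compounds, the other such pair, at the oxan-4-yl site, gives a 2.0-fold lower number from compound 1 to compound 3 (0.30 log units; within the scatter), which stays within the scatter, so cyanomethoxy to methoxy is the first change with a readable effect on the number. With the core of compound 1 held constant, the loss of the cyano group alone accompanies this step, but no available evidence accounts for it.

On these data alone, the change is read on a single pair, so whether a similar step would appear on the core of compound 2 or the core of compound 3 remains open. Also open, as far as these compounds go, is how the same chain carbon would respond to other groups, such as a hydroxyl, an amine, a carboxylic acid or a longer chain ending in a nitrile, and whether any of these would match cyanomethoxy.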